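A few compounds are considered here, and "the series" means these few. Any claim that something is new, unique, unknown or untested is made for them only; others in the source may bear on it.

Compound 2 `Nc1ncccc1-c1nc2cccnc2n1-c1ccc(CNC(=O)C2CCCCC2)cc1` shows the higher of the two numbers recorded so far: in an in vitro assay on Sf9 cells for binding affinity to RAC-alpha serine/threonine-protein kinase (Homo sapiens), tested at 30 uM (on this read-out higher numbers stand for stronger stabilisation of the target against heat and lower numbers for weaker stabilisation of the target), compound 2 gives 5.7 degrees C, whereas in this assay compound 1 `CC(C)(C)c1ccc(-n2c(-c3cccnc3N)nc3cc(Br)cnc32)cc1` gives 0.9 degrees C, a gap that lies beyond the usual scatter. Compound 3 `CC(=O)NCc1ccc(-n2c(-c3cccnc3N)nc3cccnc32)cc1` has not yet been measured. It differs from compound 2 in a single place: methyl in place of cyclohexyl on a carbonyl carbon. Going by the values given here, since no measured pair illustrates a change of this kind, the step is expected to be a loss well beyond the scatter, a number 2.9 degrees C lower from compound 2 to compound 3 (beyond the scatter). Compound 3 is therefore estimated at 2.8 degrees C, with a range from 1 degrees C to 4.8 degrees C.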

Compound 3, shift of the target's melting temperature: 2.3 degrees C
Compound 3: the middle estimate sits 0.50 degrees C above what was measured; measured number inside the range.
By their numbers in this assay, from the lowest: compound 1; then compound 3; then compound 2.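

In this assay, going by these compounds alone, putting methyl in place of cyclohexyl on a carbonyl carbon gives a number 3.4 degrees C lower from compound 2 to compound 3 (beyond the scatter) and so shows for the first time that the group at this place bears on the read-out. Compound 1 differs from compound 2 in more than one place and could not show this. Nothing available explains the step.

The compounds shown leave open whether a phenyl ring, a longer alkyl chain or an amine on this carbonyl carbon would keep the number of compound 2 or lose it as methyl does.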